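Trading the Selenium Group for 2-Aminoethoxy

The source may report more compounds than this note shows. Statements on the series, on what has been measured and on what is new or still open speak of the compounds shown alone.

In a functional assay on MDA-MB-231 cells (Homo sapiens) for inhibition, read by MTT assay, with a stated time of 48 h (on this read-out higher numbers stand for weaker inhibition and lower numbers for stronger inhibition), compound 1 `C[Se]c1ccc(N(C)c2nc(C3CC3)nc3ccccc23)cc1` gives 18 nM. Compound 2 `COc1ccc(N(C)c2nc(C)nc3ccccc23)cc1[Se]C` gives 10 nM, and the two values lie within the usual scatter of each other. Compound 3 `COc1ccc(N(C)c2nc(C)nc3ccccc23)cc1OCCN` differs from compound 2 in one place: a group of 4 heavy atoms (2 carbon, 1 nitrogen, 1 oxygen; no ring) in place of a group of 2 heavy atoms (1 carbon, 1 selenium; no ring), on an aromatic carbon. A 2-aminoethoxy group takes the place of the selenium-bearing group, on an aromatic carbon ortho to a methoxy group and meta to a large group. Within the data shown here, both measured compounds carry the selenium-bearing group, and no measured pair shows what removing it does, so the expectation rests on the structural change alone and stays wide. In this assay the expected step is a 15-fold higher number from compound 2 to compound 3 (1.18 log units; beyond the scatter), an estimated weakening beyond the scatter. For compound 3 the estimated value is 150 nM, with an expected range of 20 nM to 1200 nM.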

Compound 3, half-maximal inhibitory concentration: 682 nM
Compound 3: middle estimate off by 4.5-fold (0.66 log units), on the low side; the range from low to high includes it.
By their numbers in this assay, from the lowest: compounds 2 and 1 (each within the scatter of the next); then compound 3.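

Among these compounds, this is the first measured pair in (this assay) that changes the group on this aromatic carbon, ortho to a methoxy group and meta to a large group, and the change is large (a 68-fold higher number from compound 2 to compound 3 (1.83 log units; beyond the scatter)). With the rest of compound 2 held constant, the number therefore depends strongly on what this position carries, and 2-aminoethoxy does not match the selenium-bearing group here, although compound 3 still gives a value of 682 nM in the nanomolar range. No measurement at hand bears on the reason for this step.

The compounds shown leave open whether the step follows from losing selenium or from the entering chain and its amine. A sulfur-bearing counterpart, a plain methoxy group or a longer chain ending in an amine would help separate these possibilities.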